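The source may report more compounds than this note shows. Statements on the series, on what has been measured and on what is new or still open speak of the compounds shown alone.

Working notes on the series, read in a functional assay on the whole organism (Hindlimb, strain albino) with Mus musculus as the target, in the maximal electroshock model, with a stated time of 0.5 h; on this read-out lower numbers stand for an effect already at smaller amounts and higher numbers for an effect only at larger amounts of compound. Three measured compounds share one core and differ only in the aryl group on a saturated ring carbon. Compound 1 (`COc1ccc(C2CC(Nc3nc4ccc(Cl)cc4s3)=NN2C(C)=O)cc1O`) gives 127 umol/kg, compound 2 (`CC(=O)N1N=C(Nc2nc3ccc(Cl)cc3s2)CC1c1ccccc1`) gives 161 umol/kg, and compound 3 (`CC(=O)N1N=C(Nc2nc3ccc(Cl)cc3s2)CC1c1ccc(O)cc1`) gives 106 umol/kg. Compound 3 thus lies within the scatter of both compound 1 and compound 2, and the three values do not separate.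

The next change leads to compound 4 (`CC(=O)N1N=C(Nc2nc3ccc(Cl)cc3s2)CC1c1ccc(Cl)cc1`), with chloro in place of hydroxy on an aromatic carbon, para to a large group: chloro in place of hydroxy on an aromatic carbon. For the measured compounds named here, no measured step brings chloro into this place, so the evidence is indirect. The closest step exchanges hydroxy for hydrogen on an aromatic carbon and shows a 1.5-fold lower number from compound 2 to compound 3 (0.18 log units; within the scatter). The two wider changes of the aryl group show a 1.3-fold higher number from compound 1 to compound 2 (0.10 log units; within the scatter) and a 1.2-fold lower number from compound 1 to compound 3 (0.08 log units; within the scatter). Since each of these steps stays within the scatter, no step beyond the scatter is expected in this assay, and no direction is favoured. The estimate for the change is a 1.1-fold higher number from compound 3 to compound 4 (0.05 log units; within the scatter). Compound 4 is expected at 120 umol/kg, with an estimated range from 60 umol/kg to 240 umol/kg.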

Compound 4, dose for half-maximal effect: 79.5 umol/kg
Compound 4: middle estimate off by 1.5-fold (0.18 log units), on the high side, and the stated range covers the measured number.
By their numbers in this assay, from the lowest: compounds 4, 3, 1 and 2 (each within the scatter of the next, the first and the last beyond it).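

For the compounds shown here, at this place on the aromatic ring, para to a large group, chloro in place of hydrogen gives the first step beyond the scatter in this assay, though a modest one: a 2.0-fold lower number from compound 2 to compound 4 (0.31 log units; beyond the scatter), whereas hydroxy in place of hydrogen stayed within it with a 1.5-fold lower number from compound 2 to compound 3 (0.18 log units; within the scatter). The hydroxy group is not required for this read-out, since chloro can replace it with a 1.3-fold lower number from compound 3 to compound 4 (0.12 log units; within the scatter), and the change from the wider aryl group, a 1.6-fold lower number from compound 1 to compound 4 (0.20 log units; within the scatter), also remains within the scatter. Nothing in hand bears on the reason for the step from hydrogen to chloro.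

As far as these compounds go, with only one halogen at one place on this ring, it remains open whether the step belongs to chloro itself or would also appear with fluoro, bromo, methyl or methoxy there. From the compounds shown here alone, it also remains open whether chloro at this place keeps its step when the acetyl group on the shared core gives way to a longer chain or the chloro on the fused ring gives way to hydrogen.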